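Swapping Oxygen for Sulfur in a Cytotoxicity Series

The compounds below may be only part of what the source reports. "The series", "measured", "known", "first", "only" and "open" are said of these compounds alone.

Three compounds in this set share a common core and have been measured for their effect on cells. Compound 1 `CC(=O)OC[C@H]1O[C@@H](CC(=O)/C=C/c2cccc(NC(=O)Nc3ccccc3)c2)[C@H](OC(C)=O)[C@@H](OC(C)=O)[C@@H]1OC(C)=O` and compound 2 `CC(=O)OC[C@H]1O[C@@H](CC(=O)/C=C/c2ccc(NC(=O)Nc3ccccc3)cc2)[C@H](OC(C)=O)[C@@H](OC(C)=O)[C@@H]1OC(C)=O` are built from the same atoms joined differently; the difference between the two cores is not broken down here. In an ADME assay on Vero cells (Chlorocebus sabaeus) for cytotoxicity, read by resazurin assay, with a stated time of 2 days (on this read-out higher numbers stand for lower toxicity in this test and lower numbers for higher toxicity in this test), compound 1 gives 180000 nM, while compound 2 gives 820000 nM, the highest of the three measured numbers, with its gaps to both other compounds lying beyond the usual scatter.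

Compound 3 `CC(=O)OC[C@H]1O[C@@H](CC(=O)/C=C/c2cccc(NC(=S)Nc3ccccc3)c2)[C@H](OC(C)=O)[C@@H](OC(C)=O)[C@@H]1OC(C)=O` arises from compound 1 by a single change, (a group of 9 heavy atoms (7 carbon, 1 nitrogen, 1 sulfur; one six-membered aromatic ring of carbon only) in place of a group of 9 heavy atoms (7 carbon, 1 nitrogen, 1 oxygen; one six-membered aromatic ring of carbon only), on a nitrogen on an aromatic ring). In this assay compound 3 gives 337000 nM, and the step of a 1.9-fold higher number from compound 1 to compound 3 (0.27 log units; within the scatter) is small enough to fall within the scatter of repeated measurements.

Compound 4 `CC(=O)OC[C@H]1O[C@@H](CC(=O)/C=C/c2ccc(NC(=S)Nc3ccccc3)cc2)[C@H](OC(C)=O)[C@@H](OC(C)=O)[C@@H]1OC(C)=O` is not yet measured. It stands to compound 2 exactly as compound 3 stands to compound 1: a group of 9 heavy atoms (7 carbon, 1 nitrogen, 1 sulfur; one six-membered aromatic ring of carbon only) in place of a group of 9 heavy atoms (7 carbon, 1 nitrogen, 1 oxygen; one six-membered aromatic ring of carbon only), on a nitrogen on an aromatic ring. The surroundings of the changed position are described in the same words for both pairs, so this is the same change applied to a second core.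

For the measured compounds named here, because the one earlier instance of this change, a 1.9-fold higher number from compound 1 to compound 3 (0.27 log units; within the scatter), stayed within the scatter, the step from compound 2 to compound 4 is expected to be similarly modest, a 1.3-fold higher number from compound 2 to compound 4 (0.13 log units; within the scatter). Compound 4 is therefore estimated at 1100000 nM in this assay, with a plausible range from 500000 nM to 2500000 nM. This expectation rests on a single measured pair, and since compound 2 already sits at the top of the measured numbers, there is a real chance that the assay reports only a limit for compound 4 rather than a number.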

Compound 4, half-maximal cytotoxic concentration: 663000 nM
Compound 4: middle estimate off by 1.7-fold (0.22 log units), on the high side; the range from low to high includes it.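

In this assay the exchange of the phenylcarbamoyl group for its sulfur-bearing counterpart, on a nitrogen on an aromatic ring, gives a 1.2-fold lower number from compound 2 to compound 4 (0.09 log units; within the scatter) on the second core, so on this core too the step stays within the usual scatter of repeated measurements. Set beside the earlier instance, the change shows no sign of depending on which of the two cores carries it, and the two steps cannot be told apart: the same change on two cores in this assay, a 1.9-fold higher number (0.27 log units; within the scatter) from compound 1 to compound 3 and a 1.2-fold lower number (0.09 log units; within the scatter) from compound 2 to compound 4, 2.3-fold (0.36 log units) apart, within the scatter of two such steps. This shows only that, for these two pairs and in this one test, the exchange of oxygen for sulfur leaves the read-out within the scatter; it does not show that the exchange is without effect in general, that it would carry to a third core, or why the two steps look as they do, and two pairs are too few to establish a rule.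

The compounds shown leave open whether the exchange stays as small when the phenyl ring of the group carries a substituent such as an amine or a carboxylic acid. They also leave open what happens when the acetyl groups give way to free hydroxyl groups.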